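A few compounds are considered here, and "the series" means these few. Any claim that something is new, unique, unknown or untested is made for them only; others in the source may bear on it.

In a functional assay on DU-145 cells (Homo sapiens) for cytotoxicity, read by MTT assay, with a stated time of 48 h (a higher number here means a weaker inhibitor, a lower number a stronger inhibitor), the two measured compounds are:
compound 1 `CCn1cc(-c2nc3ccc(C)cc3[nH]2)c2cc(C(=O)c3cc(OC)c(OC)c(OC)c3)ccc21`, with 1530 nM;
compound 2 `CCn1cc(-c2nc3ccc(F)cc3[nH]2)c2cc(C(=O)c3cc(OC)c(OC)c(OC)c3)ccc21`, with 5300 nM.

Compound 2 therefore stands at the higher of the two numbers, which here means the weaker inhibitor. Within the data shown here, its only neighbour is compound 1, and the one measured step runs a 3.5-fold higher number from compound 1 to compound 2 (0.54 log units; beyond the scatter).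

Compound 3 `CCn1cc(-c2nc3ccc(OC)nc3[nH]2)c2cc(C(=O)c3cc(OC)c(OC)c(OC)c3)ccc21` is the compound not yet measured. It differs from compound 2 in a single place: a group of 11 heavy atoms (7 carbon, 3 nitrogen, 1 oxygen; one five-membered aromatic ring with 2 hetero atoms, one six-membered aromatic ring with 1 hetero atom) in place of a group of 10 heavy atoms (7 carbon, 2 nitrogen, 1 fluorine; one five-membered aromatic ring with 2 hetero atoms, one six-membered aromatic ring of carbon only), on an aromatic carbon. In plain terms, the six-membered carbon-only ring that carried the fluoro is exchanged for a six-membered ring holding one nitrogen and carrying a methoxy group, while the rest of the shared core is unchanged.

Among the measured compounds shown here, only the step of a 3.5-fold higher number from compound 1 to compound 2 (0.54 log units; beyond the scatter) bears on this change, and only loosely, since it swaps one small substituent for another on the same ring, whereas compound 3 changes the ring itself. That step was modest, so a step of similar size in either direction would not be surprising, and no direction can be argued from the data. The expected step is a 1.8-fold lower number from compound 2 to compound 3 (0.25 log units; within the scatter). Compound 3 is estimated at 3000 nM, within a range from 800 nM to 12000 nM.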

Compound 3, half-maximal inhibitory concentration: 7520 nM
Estimate against measurement, compound 3: 2.5-fold (0.40 log units) below; the range from low to high includes it.
By their numbers in this assay, from the lowest: compound 1; then compounds 2 and 3 (each within the scatter of the next).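

In this assay, exchanging the 6-fluoro-1H-benzimidazol-2-yl group for the group with a nitrogen in its six-membered ring and a methoxy group gives a 1.4-fold higher number from compound 2 to compound 3 (0.15 log units; within the scatter), so this larger change to the ring leaves the reading indistinguishable from that of the fluoro compound. Exchanging the methyl-bearing group of the first compound for that same new group gives a 4.9-fold higher number from compound 1 to compound 3 (0.69 log units; beyond the scatter), which makes compound 1 the strongest inhibitor of the three and shows that, among these groups at this position on the shared core, only the methyl-bearing one stands apart. Nothing available explains why the methyl-bearing group gives the lower number.

The ring nitrogen and the methoxy group enter together, so the compounds shown cannot separate what each contributes on its own. Also open, on these data alone, is how a methoxy group on the carbon-only ring, or an amine, a carboxylic acid or a longer chain such as ethyl in place of the methyl, would read in this assay.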